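Adding a Methoxy to an Inactive Alkynyl Sulfonamide Core

The compounds below may be only part of what the source reports. "The series", "measured", "known", "first", "only" and "open" are said of these compounds alone.

Compound 1 `O=S(=O)(Nc1ccc(F)c(C#Cc2cnc3[nH]ncc3c2)c1F)c1cccnc1` was examined in a functional assay on HCT-116 cells (Homo sapiens) for antiproliferative activity, read by MTT assay, with a stated time of 68 h; a higher number here means a weaker inhibitor, a lower number a stronger inhibitor. In this assay compound 1 gives only a limit of the assay, > 10000 nM, so no number is known for it. Compound 2 `O=S(=O)(Nc1ccc(F)c(C#Cc2cnc3[nH]ccc3c2)c1F)c1cccnc1` differs from compound 1 on a triple-bonded carbon, where a group of 9 heavy atoms (7 carbon, 2 nitrogen; one five-membered aromatic ring with 1 hetero atom, one six-membered aromatic ring with 1 hetero atom) stands in place of a group of 9 heavy atoms (6 carbon, 3 nitrogen; one five-membered aromatic ring with 2 hetero atoms, one six-membered aromatic ring with 1 hetero atom). In this assay compound 2 likewise gives only a limit, > 10000 nM. The step that the two limits leave unreadable from compound 1 to compound 2 is therefore unreadable, since both values sit at the limit of > 10000 nM in this assay, at which 2 of the 2 values shown sit.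

Compound 3 `COc1n[nH]c2ncc(C#Cc3c(F)ccc(NS(=O)(=O)c4cccnc4)c3F)cc12` keeps the core of compound 1 and carries methoxy in place of hydrogen on an aromatic carbon, the methoxy sitting on an aromatic carbon of a five-membered aromatic ring with 2 nitrogen, part of a fused or bridged system of two rings. Within the data shown here, no measured step bears on a change of this kind, and both known values are limits rather than numbers. The step from compound 1 to compound 3 is accordingly expected to be a step that the limit leaves unreadable from compound 1 to compound 3, nothing readable beyond the scatter. Compound 3 is estimated at 15000 nM in this assay, between 4000 nM and 60000 nM, most probably reported again only as a limit.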

Compound 3, half-maximal inhibitory concentration: 1280 nM
For compound 3 the middle estimate is 12-fold (1.07 log units) above the measured one, outside the stated range (below it).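

Compound 3 is the only one of the three compounds that gives a number rather than a limit: the limit of > 10000 nM in this assay, at which 2 of the 3 values shown sit.

In this assay, methoxy in place of hydrogen on an aromatic carbon of the five-membered aromatic ring with 2 nitrogen gives an at least 7.8-fold lower number from compound 1 to compound 3 (0.89 log units; beyond the scatter), so this aromatic carbon is a place where a single small change on the core of compound 1 brings a readable value, which the unreadable step between the two earlier compounds could not show. On these data alone, the true size of this step remains open, as only one of its two ends is a number.

The compounds shown leave open whether an ethoxy, an amine or a chlorine on the same aromatic carbon would give a similar value or a stronger one, and so whether the oxygen of the methoxy matters or any group in place of hydrogen would serve. They also leave open whether a methoxy would have a comparable effect on the core of compound 2, and they say nothing about why the methoxy brings this change.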